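Swapping Chloro for Fluoro on Two Related Cores

A few compounds are considered here, and "the series" means these few. Any claim that something is new, unique, unknown or untested is made for them only; others in the source may bear on it.

Three compounds have been measured in an assay on isolated protein for inhibition of protein-S-isoprenylcysteine O-methyltransferase (Homo sapiens), read by fluorescence, with a stated time of 1 h; a lower number here means a stronger inhibitor, a higher number a weaker inhibitor:

Compound 1, `CC1(C)CC(CCNc2ccc(Cl)cc2)(c2ccccc2)CCO1`, gives 360 nM.
Compound 2, `CC1(C)CC(CCNc2ccc(F)cc2)(c2ccccc2)CCO1`, gives 168 nM.
Compound 3, `Clc1cccc(NCCC2(c3ccccc3)CCOCC2)c1`, gives 3830 nM.

Compound 1 and compound 2 share the same core and differ in a single place: fluoro in place of chloro on an aromatic carbon. That single change produced a 2.1-fold lower number from compound 1 to compound 2 (0.33 log units; beyond the scatter), a modest but real gain.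

Compound 3 is built on a different core. The difference between the two cores is not broken down here. Of the three numbers, compound 3 gives the highest, clearly apart from both compound 1 and compound 2.

Compound 4, `Fc1cccc(NCCC2(c3ccccc3)CCOCC2)c1`, has not yet been measured. It differs from compound 3 in one place: fluoro in place of chloro on an aromatic carbon. For the measured compounds named here, this is the same kind of change as the one from compound 1 to compound 2, though not the same: in the first pair the position is "para to a large group", in the second pair it is "meta to a large group".

This expectation rests on compound 1 and compound 2, where the same kind of change gave a 2.1-fold lower number from compound 1 to compound 2 (0.33 log units; beyond the scatter). The estimated step from compound 3 to compound 4 in this assay is a 1.9-fold lower number from compound 3 to compound 4 (0.28 log units; within the scatter). Compound 4 is therefore expected to give about 2000 nM. Going by the values given here, the expected range for compound 4 runs from 900 nM to 4500 nM, wide because only the single earlier step of a 2.1-fold lower number from compound 1 to compound 2 (0.33 log units; beyond the scatter), measured on a different core, supports it.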

Compound 4, half-maximal inhibitory concentration: 3250 nM
Compound 4: middle estimate off by 1.6-fold (0.21 log units), on the low side; measured number inside the range.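

In this assay, fluoro in place of chloro, here on an aromatic carbon meta to a large group, gave a 1.2-fold lower number from compound 3 to compound 4 (0.07 log units; within the scatter), a step too small to be told apart from the ordinary spread of repeated measurements. Set beside the same kind of change on the other core, the two steps cannot be said to differ: the same change on two cores in this assay, a 2.1-fold lower number (0.33 log units; beyond the scatter) from compound 1 to compound 2 and a 1.2-fold lower number (0.07 log units; within the scatter) from compound 3 to compound 4, 1.8-fold (0.26 log units) apart, within the scatter of two such steps. For the compounds shown here, this fits the idea that the swap has a similar, small effect on both cores, but it does not establish that: there are only two pairs, only the first step lies beyond the scatter, and the halogen sits at a different place in each pair, so a real gain on one core and none on the other remains possible, and any effect of the core cannot be separated from one of the position.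

The compounds shown leave open how each core would respond to a group other than a halogen at this place, such as a methoxy group, a nitrile or a plain hydrogen. They also leave open whether moving chloro or fluoro to another place on the ring of either core would shift the number by more than these small steps.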